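Swapping Chloro for Methoxy on Compound 2

The compounds below may be only part of what the source reports. "The series", "measured", "known", "first", "only" and "open" are said of these compounds alone.

Among the measured compounds shown here, only two compounds have been measured so far. In a functional assay on HL-60 cells (Homo sapiens) for inhibition, read by MTT assay, with a stated time of 48 h (a lower number here means a stronger inhibitor, a higher number a weaker inhibitor), compound 2 `O=C(Nc1nc2ccc([N+](=O)[O-])cc2s1)c1cccnc1Nc1ccc(Cl)cc1` gives 400 nM. For the measured compounds named here, its one neighbour, compound 1 `O=C(Nc1nc2ccc([N+](=O)[O-])cc2s1)c1cccnc1Nc1ccc(F)cc1`, gives 300 nM in this assay, and the single measured step, a 1.3-fold higher number from compound 1 to compound 2 (0.12 log units; within the scatter), lies within the scatter, so the two stand level. Compound 3 `COc1ccc(Nc2ncccc2C(=O)Nc2nc3ccc([N+](=O)[O-])cc3s2)cc1` carries the change (methoxy in place of chloro on an aromatic carbon). Going by the values given here, no measured step shows a methoxy entering, and the halogen swap barely moved the number, so the expected step is no change at the digits printed from compound 2 to compound 3 (within the scatter), nothing beyond the scatter. Compound 3 is therefore estimated at 400 nM, within 150 nM to 1200 nM.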

Compound 3, half-maximal inhibitory concentration: 700 nM
For compound 3 the middle estimate is 1.8-fold (0.24 log units) below the measured one; low and high end bracket the measured number.
By their numbers in this assay, from the lowest: compounds 1, 2 and 3 (each within the scatter of the next, the first and the last beyond it).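

In this assay, among the compounds shown here, methoxy on this aromatic carbon, para to a large group, gives the first step that lies beyond the scatter (a 2.3-fold higher number from compound 1 to compound 3 (0.37 log units; beyond the scatter)). Against chloro the same change stays within the scatter (a 1.8-fold higher number from compound 2 to compound 3 (0.24 log units; within the scatter)), so the shift is modest and shows only against fluoro. Nothing available explains this difference between the groups. Going by these compounds, whether an amine, a hydroxyl or a longer chain such as ethoxy would hold the number at this position remains open. So does whether any group here could bring it lower than compound 1 does.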